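The source may report more compounds than this note shows. Statements on the series, on what has been measured and on what is new or still open speak of the compounds shown alone.

Measured compounds so far:
compound 1, `CCOC(=O)CN(Cc1cc(F)cc(F)c1)c1ccc2c(c1)OC(C)(COc1ccc(C#N)cc1)CN2C`, > 100000 nM
compound 2, `CCOC(=O)C(=O)N(Cc1cc(F)cc(F)c1)c1ccc2c(c1)OC(C)(CO)CN2C`, 44000 nM

Of the compounds shown here, two with a shared core have been tested in a functional assay on HeLa cells (Homo sapiens) for antiproliferative activity, read by cell counting, with a stated time of 4 days; a lower number here means a stronger inhibitor, a higher number a weaker inhibitor. Compound 1 sits at the limit of > 100000 nM in this assay, at which 1 of the 2 values shown sits. For compound 1 that value is a limit of this assay and not a number. Among the compounds with values here, compound 2 gives 44000 nM in this assay, and that is the only actual number among the two, so compound 2 stands alone as the reference point for what follows.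

Compound 3, `CCOC(=O)C(=O)N(Cc1ccccc1)c1ccc2c(c1)OC(C)(CO)CN2C`, has not yet been measured. It differs from compound 2 by phenyl in place of 3,5-difluorophenyl on a saturated chain carbon bound to an amide-type nitrogen. Within the data shown here, no measured pair of compounds differs in exactly this way, so the size of the step is not known from the data. The step of a 1.4-fold higher number from compound 2 to compound 3 (0.13 log units; within the scatter) is expected to be small, within the scatter of repeated measurements or at most a modest loss. Compound 3 is therefore estimated at 60000 nM in this assay, in a range from 20000 nM to 200000 nM.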

Compound 3, half-maximal inhibitory concentration: > 100000 nM
Compound 3: only a limit was reported (the forecaster's own chance of this, stated with the estimate: 35%); at least 1.6-fold (0.22 log units) between middle value and limit.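

In this assay compound 3 gives > 100000 nM, which is a limit of the assay and not a number. Within the data shown here, the change from 3,5-difluorobenzyl to benzyl is the first change in one place that can be read, and it comes to an at least 2.2-fold higher number from compound 2 to compound 3 (0.35 log units; beyond the scatter), so on this saturated chain carbon bound to an amide-type nitrogen the fluorine atoms cannot be lost without a change beyond the scatter. The true size of the step stays hidden, as compound 3 now sits at the same limit as compound 1: the limit of > 100000 nM in this assay, at which 2 of the 3 values shown sit.

As far as these compounds go, how far compound 3 lies past its limit remains open. Also open, from the compounds shown here alone, is whether a chlorine or a trifluoromethyl group on the phenyl would hold the value of compound 2, 44000 nM, and whether a carboxylic acid in place of the ethyl ester would move it.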